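Swapping 1-aminocyclopentyl for 1-hydroxy-2-methylpropyl on the shared core

This account rests on a few compounds, and the source may have more. Where it says the series, first, only, none or still open, it means among the compounds named here.

Three compounds share one core and differ only in the group on a carbonyl carbon: compound 1 `Cc1c2c(n3c1CCN(C(=O)CN)C[C@@H](C)[C@H](C)Nc1cc-3ccc1C(N)=O)CC(C)(C)CC2=O`, compound 2 `Cc1c2c(n3c1CCN(C(=O)C(C)(C)N)C[C@@H](C)[C@H](C)Nc1cc-3ccc1C(N)=O)CC(C)(C)CC2=O` and compound 3 `Cc1c2c(n3c1CCN(C(=O)C1(N)CCCC1)C[C@@H](C)[C@H](C)Nc1cc-3ccc1C(N)=O)CC(C)(C)CC2=O`. In a functional assay on HCT-116 cells (Homo sapiens) for antiproliferative activity (a lower number here means a stronger inhibitor, a higher number a weaker inhibitor), compound 1 gives 216 nM, compound 2 gives 25 nM and compound 3 gives 27 nM. The data show a 1.1-fold higher number from compound 2 to compound 3 (0.03 log units; within the scatter), so compound 3 stands together with compound 2 at the low end of these numbers. Both sit clearly apart from the aminomethyl group of compound 1, with an 8.6-fold lower number from compound 1 to compound 2 (0.94 log units; beyond the scatter) and an 8.0-fold lower number from compound 1 to compound 3 (0.90 log units; beyond the scatter).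

Compound 4 `Cc1c2c(n3c1CCN(C(=O)[C@@H](O)C(C)C)C[C@@H](C)[C@H](C)Nc1cc-3ccc1C(N)=O)CC(C)(C)CC2=O` changes the same group again: 1-hydroxy-2-methylpropyl in place of 1-aminocyclopentyl on a carbonyl carbon. Its new group holds oxygen where the old one holds nitrogen, and it has no ring. Within the data shown here, every measured group carries that nitrogen, so no measured step tests this swap directly. Among the measured compounds shown here, the modest steps of an 8.6-fold lower number from compound 1 to compound 2 (0.94 log units; beyond the scatter) and an 8.0-fold lower number from compound 1 to compound 3 (0.90 log units; beyond the scatter) show only that this group can move the number in this assay. Losing the nitrogen is an untested change, so a smaller step towards a higher number is expected, and the estimate is a 2.6-fold higher number from compound 3 to compound 4 (0.41 log units; beyond the scatter). Compound 4 is estimated at 70 nM, within an expected range from 18 nM to 270 nM.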

Compound 4, half-maximal inhibitory concentration in the HCT-116 assay: 45 nM
Beside the measured number, compound 4's estimate is 1.6-fold (0.19 log units) above it; low and high end bracket the measured number.
By their numbers in the HCT-116 assay, from the lowest: compounds 2, 3 and 4 (each within the scatter of the next); then compound 1.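

In the HCT-116 assay, compound 2 gives 25 nM, compound 3 gives 27 nM and compound 4 gives 45 nM, and the nitrogen of the group on this carbonyl carbon proves dispensable among these compounds: with oxygen in its place and no ring, the steps are a 1.7-fold higher number from compound 3 to compound 4 (0.22 log units; within the scatter) and a 1.8-fold higher number from compound 2 to compound 4 (0.26 log units; within the scatter), so these three compounds cannot be told apart. The separation from the aminomethyl group also survives without that nitrogen, as a 4.8-fold lower number from compound 1 to compound 4 (0.68 log units; beyond the scatter) shows, and of the four groups, aminomethyl is the only one with no branch, although four compounds show only a pattern and not its cause. In a physicochemical assay for solubility, at pH 7.4 (a lower number here means a less soluble compound, a higher number a more soluble compound), compound 3 gives 53 ug/mL and compound 4 gives 30 ug/mL, and the same swap is a step of a 1.8-fold lower number from compound 3 to compound 4 (0.25 log units; within the scatter), so this change shows no clear difference in that read-out either.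

Nothing shown here explains why the three branched groups differ from aminomethyl. Going by these compounds, it remains open whether the defined stereocentre of 1-hydroxy-2-methylpropyl matters, and whether a hydroxymethyl group, the unbranched oxygen counterpart of aminomethyl, would stand with compound 1 or with the other three compounds.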